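A few compounds are considered here, and "the series" means these few. Any claim that something is new, unique, unknown or untested is made for them only; others in the source may bear on it.

Measured so far in a functional assay on A-375 cells (Homo sapiens) for antiproliferative activity, read by MTT assay, with a stated time of 24 h, tested at 100 ug/mL; a lower number here means a weaker effect, a higher number a stronger effect of the compound at the concentration tested:
compound 1 `Cc1ccc2nc(C(=O)Nc3c(F)cc(-c4cccc(F)c4)cc3F)c(C)c(C(=O)O)c2c1` gives 37.3%
compound 2 `CCOc1ccc2nc(C(=O)Nc3c(F)cc(-c4cccc(F)c4)cc3F)c(C)c(C(=O)O)c2c1` gives 72.4%

Compound 2 stands highest of the two numbers; its nearest neighbour is compound 1, and the step of a number 35.1 percentage points higher from compound 1 to compound 2 (beyond the scatter) is large. Compound 3 `Cc1c(C(=O)Nc2c(F)cc(-c3cccc(F)c3)cc2F)nc2ccc(C(F)(F)F)cc2c1C(=O)O` differs from compound 2 by trifluoromethyl in place of ethoxy on an aromatic carbon. Among the measured compounds shown here, no measured step concerns trifluoromethyl; the one step known, a number 35.1 percentage points higher from compound 1 to compound 2 (beyond the scatter), only shows that the ethoxy of compound 2 sits with the higher value. Since that group now leaves, compound 3 is expected to fall back toward the range of compound 1, by an estimated a number 24.4 percentage points lower from compound 2 to compound 3 (beyond the scatter). Compound 3 is therefore estimated at 48%, within 25% to 75%.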

Compound 3, a percentage reported as inhibition, at one concentration (the size of the read-out at that concentration, not a potency): 61.3%
Estimate against measurement, compound 3: 13.3 percentage points below; the range from low to high includes it.
By their numbers in this assay, from the lowest: compound 1; then compound 3; then compound 2.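

In this assay, the rise over methyl at this position does not depend on ethoxy alone: trifluoromethyl also gives a number 24 percentage points higher from compound 1 to compound 3 (beyond the scatter). Ethoxy nevertheless keeps an edge, with trifluoromethyl in its place giving a number 11.1 percentage points lower from compound 2 to compound 3 (beyond the scatter), so the two replacements are not equivalent here. Nothing available accounts for this order. The compounds shown leave open how an amine, a nitrile or a longer alkoxy chain would read at this position. They also leave open whether the same order would hold at other concentrations.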